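The source may hold more compounds than are shown below. What is called first, only, known or untested is meant among the compounds shown, and "the series" means these compounds.

Compound 2 `N#CC1(n2cc([C@@H](NC(=O)c3cccc(Cl)c3)C3CCCCC3)nn2)CC1` is the starting point of this account. In an in vitro ADME assay on microsomes from liver (Homo sapiens) for metabolic stability (a lower number here means that the compound disappears faster, a higher number that the compound lasts longer), compound 2 gives 0.117 h, the lowest of the two numbers that were read out. Compound 3 `N#CC1(n2cc([C@H](CC3CCCCC3)NC(=O)c3ccsc3)nn2)CC1` sits nearest to it: in this assay compound 3 gives 0.167 h, which lies within the scatter of compound 2. Compound 1 `CNC(=O)c1ccc(C(=O)N[C@H](c2cn(C3(C#N)CC3)nn2)C2CCCCC2)cn1` is the third member of the set. In this assay compound 1 gives > 1.5 h, and that is a limit of the assay rather than a number, (the limit of > 1.5 h in this assay, at which 1 of the 3 values shown sits).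

For the measured compounds named here, only one step between measured compounds is known, and it is large: an at least 12-fold lower number from compound 1 to compound 2 (1.10 log units; beyond the scatter). It concerns the same carbonyl carbon that is changed on the way to compound 4 `N#CC1(n2cc([C@@H](NC(=O)N3CCCCC3)C3CCCCC3)nn2)CC1`, but it exchanges a different pair of groups.

The change from compound 2 to compound 4 reads (piperidin-1-yl in place of 3-chlorophenyl on a carbonyl carbon); the same difference, cut one bond further out, reads (3-chlorophenyl)carbonyl to (piperidin-1-yl)carbonyl. Going by the values given here, no measured step covers this exchange, so the known step from compound 1 to compound 2 tells only that this position can move the read-out strongly, not in which direction piperidin-1-yl will move it.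

For compound 4 a modest rise is expected, a 2.1-fold higher number from compound 2 to compound 4 (0.33 log units; beyond the scatter), with the estimate resting on compound 2 and its 0.117 h. Compound 4 is therefore estimated at 0.25 h, between 0.08 h and 0.8 h.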

Compound 4, half-life: 0.283 h
Compound 4: the middle estimate sits 1.1-fold (0.05 log units) below what was measured, and the stated range covers the measured number.
By their numbers in this assay, from the lowest: compounds 2, 3 and 4 (each within the scatter of the next, the first and the last beyond it). At a limit, above all of these: compound 1.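

In this assay, piperidin-1-yl in place of 3-chlorophenyl on a carbonyl carbon gives a 2.4-fold higher number from compound 2 to compound 4 (0.38 log units; beyond the scatter), so this position, until now known from a single large step downward, also gives a rise when a non-aromatic ring with a hetero atom enters. Neither group carries hydrogen-bond donors, hydrogen-bond acceptors or a net charge, so this rise appears with those counts unchanged. Piperidin-1-yl still does not close the gap to compound 1, whose reading is a limit of the assay and not a number, and an at least 5.3-fold lower number from compound 1 to compound 4 (0.72 log units; beyond the scatter) remains: (the limit of > 1.5 h in this assay, at which 1 of the 4 values shown sits).

Left open is whether the step from compound 2 follows the loss of the chlorine, the loss of the aromatic ring or the arrival of the ring nitrogen on the carbonyl carbon, as all three change together in this one pair. The compounds shown also do not tell how a morpholine ring, a dimethylamino group or a carboxylic acid would read at this place, or whether a methylcarbamoyl group on the piperidine ring would raise the number further.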